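This account rests on a few compounds, and the source may have more. Where it says the series, first, only, none or still open, it means among the compounds named here.

Two compounds with a measured half-life frame this account. Compound 1 `O=C(CCc1nnnn1-c1cccc2ccccc12)Nc1ccccc1[N+](=O)[O-]` is one of them; in an in vitro ADME assay on microsomes from liver (Homo sapiens) for metabolic stability (on this read-out lower numbers stand for a shorter-lived compound and higher numbers for a longer-lived compound), compound 1 gives 0.117 h. Compound 2 `CC(C)(C)c1ccc(-n2nnnc2SCC(=O)Nc2ccccc2Cl)c(Cl)c1` is the other; in this assay compound 2 gives 0.133 h. The two values lie within the scatter of each other, so compound 2 cannot be set apart from compound 1 on these numbers alone.

Compound 3 `CC(C)(C)c1ccc(-n2nnnc2SCC(=O)Nc2ccc(-c3ccc(CC(=O)O)cc3)cc2Cl)c(Cl)c1` has not been measured. It differs from compound 2 in one place: 4-(carboxymethyl)phenyl in place of hydrogen on an aromatic carbon. Among the measured compounds shown here, no measured pair shows the effect of such a change, so the expected size of the step rests on the structural change alone. Compound 3 is expected to show a longer half-life than compound 2, with the step from compound 2 to compound 3 estimated as a 1.9-fold higher number from compound 2 to compound 3 (0.27 log units; within the scatter). Compound 3 is therefore estimated at 0.25 h, within a range from 0.1 h to 0.8 h.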

Compound 3, half-life: 0.383 h
Compound 3: middle estimate off by 1.5-fold (0.19 log units), on the low side, within the range that was stated.
By their numbers in this assay, from the lowest: compounds 1 and 2 (each within the scatter of the next); then compound 3.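

In this assay, the aromatic carbon meta to a chloro group and para to a large group accepts a substituent as large as 4-(carboxymethyl)phenyl, and this change gives a 2.9-fold higher number from compound 2 to compound 3 (0.46 log units; beyond the scatter). Among the compounds shown here, the half-life therefore moves upward here by more than the usual scatter, something the earlier compounds could not show, as they offered no pair differing in one place. Still, this rests on a single pair, and nothing shown bears on why the number rises.

From the compounds shown here alone, it remains open whether the benzene ring or the carboxylic acid carries the step, which a plain phenyl group, or an ester or amide in place of the acid, could separate. Also open, going by these compounds, is whether a shorter chain to the acid, or the same group at another ring carbon, would give a similar step.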